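Swapping the Hexyl Tail of Compound 3 for Phenyl

A few compounds are considered here, and "the series" means these few. Any claim that something is new, unique, unknown or untested is made for them only; others in the source may bear on it.

Compound 3 `CCCCCCCCC#Cc1ccc(S(=O)(=O)Nc2cccc(-c3csc(NC(C)=O)n3)c2)cc1` gives 39.6% in a functional assay on A-375 cells (Homo sapiens) for antiproliferative activity, read by trypan blue exclusion, with a stated time of 48 h, tested at 1 uM (a higher number here means a weaker effect of the compound at the concentration tested, a lower number a stronger effect), at the low end of the three numbers measured, though not separated from compound 1 beyond the scatter. Compound 1 `CCCCCCC#Cc1ccc(S(=O)(=O)Nc2cccc(-c3csc(NC(C)=O)n3)c2)cc1` gives 40.7% in this assay, and compound 2 `C#Cc1ccc(S(=O)(=O)Nc2cccc(-c3csc(NC(C)=O)n3)c2)cc1` gives 59.2%. Compound 4 `CC(=O)Nc1nc(-c2cccc(NS(=O)(=O)c3ccc(C#CCCc4ccccc4)cc3)c2)cs1` differs from compound 3 by phenyl in place of hexyl on a saturated chain carbon, two bonds along the chain from a triple-bonded carbon. For the measured compounds named here, the steps that bear on this are a number 19.6 percentage points lower from compound 2 to compound 3 (beyond the scatter) and a number 18.5 percentage points higher from compound 1 to compound 2 (beyond the scatter), which show that a chain on the triple-bonded carbon lowers the number, while a number 1.1 percentage points lower from compound 1 to compound 3 (within the scatter) shows that the chain's length beyond that matters little. Since compound 4 keeps a saturated chain on that carbon, now ending in phenyl, the expected step is a number 1.4 percentage points higher from compound 3 to compound 4 (within the scatter), none beyond the scatter. Compound 4 is therefore estimated at 41%, between 30% and 53%.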

Compound 4, a percentage reported as activity, at one concentration (the size of the read-out at that concentration, not a potency): 11.5%
Beside the measured number, compound 4's estimate is 29.5 percentage points above it, outside the stated range (below it).
By their numbers in this assay, from the lowest: compound 4; then compounds 3 and 1 (each within the scatter of the next); then compound 2.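

The end of the chain on the triple-bonded carbon counts in this assay where its length had not: phenyl in place of hexyl gives a number 28.1 percentage points lower from compound 3 to compound 4 (beyond the scatter) and phenyl in place of butyl gives a number 29.2 percentage points lower from compound 1 to compound 4 (beyond the scatter) at the same place. Phenethyl in place of hydrogen gives a number 47.7 percentage points lower from compound 2 to compound 4 (beyond the scatter) on that triple-bonded carbon, so among these compounds the chain ending in phenyl lowers the number further than the chains without a ring. Nothing measured here accounts for this. On these data alone, whether a benzyl or a longer phenylalkyl chain in place of phenethyl, or a pyridine ring or an amine at the chain end, would keep the number this low stays open.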